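The source may report more compounds than this note shows. Statements on the series, on what has been measured and on what is new or still open speak of the compounds shown alone.

Of the compounds shown here, three built on a shared core have been measured in a functional assay on CCRF-CEM cells (Homo sapiens); on this read-out lower numbers stand for higher toxicity in this test and higher numbers for lower toxicity in this test. Compound 1 `CCOC(=O)NC(=O)NC1=CS(=O)(=O)O[C@@]12[C@@H](CO[Si](C)(C)C(C)(C)C)O[C@@H](n1cc(C)c(=O)n(C)c1=O)[C@@H]2O[Si](C)(C)C(C)(C)C` gives 3000 nM in this assay. Compound 2 `CCNC(=O)NC1=CS(=O)(=O)O[C@@]12[C@@H](CO[Si](C)(C)C(C)(C)C)O[C@@H](n1cc(C)c(=O)n(C)c1=O)[C@@H]2O[Si](C)(C)C(C)(C)C` gives 4260 nM in this assay, and the step of a 1.4-fold higher number from compound 1 to compound 2 (0.15 log units; within the scatter) stays within the scatter. Compound 3 `Cc1cn([C@@H]2O[C@H](CO[Si](C)(C)C(C)(C)C)[C@@]3(OS(=O)(=O)C=C3NCCC(=O)OCc3ccccc3)[C@H]2O[Si](C)(C)C(C)(C)C)c(=O)n(C)c1=O` stands apart from both. In this assay compound 3 reaches only a limit of the measurement, > 250000 nM, so no number is known for it. The steps of an at least 83-fold higher number from compound 1 to compound 3 (1.92 log units; beyond the scatter) and an at least 58-fold higher number from compound 2 to compound 3 (1.76 log units; beyond the scatter) are both large, and both rest on the same limit (the limit of > 250000 nM in this assay, at which 1 of the 3 values shown sits).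

Compound 4 `Cc1cn([C@@H]2O[C@H](CO[Si](C)(C)C(C)(C)C)[C@@]3(OS(=O)(=O)C=C3NCC(=O)C(=O)N3CCC3)[C@H]2O[Si](C)(C)C(C)(C)C)c(=O)n(C)c1=O` has not yet been measured in this assay. It differs from compound 3 in one place: ((azetidin-1-yl)carbonyl)carbonyl in place of (benzyloxycarbonyl)methyl on a saturated chain carbon bound to an amine nitrogen. Among the compounds with values here, no measured pair shows this change, so only the position of compound 3 guides the expectation. The two large steps leading to compound 3 both arose when a carbamoyl group on the amine nitrogen gave way to a 2-(benzyloxycarbonyl)ethyl chain, and compound 4 keeps a chain on that nitrogen. Compound 4 is therefore expected to show an estimated step of an at least 1.6-fold lower number from compound 3 to compound 4 (0.22 log units; that floor lies within the scatter) that stays within the scatter. For compound 4 the estimate in this assay is 150000 nM, with a range from 15000 nM to 400000 nM, and a fair chance that only a limit is reported again.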

Compound 4, half-maximal cytotoxic concentration: 21600 nM
Compound 4: the middle estimate sits 6.9-fold (0.84 log units) above what was measured; measured number inside the range.
By their numbers in this assay, from the lowest: compounds 1 and 2 (each within the scatter of the next); then compound 4. At a limit, above all of these: compound 3.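

In this assay, as far as these compounds go, this position proves to respond to what the chain on the amine nitrogen carries, and not only to whether a chain stands there: placing ((azetidin-1-yl)carbonyl)carbonyl in place of (benzyloxycarbonyl)methyl gives an at least 11-fold lower number from compound 3 to compound 4 (1.06 log units; beyond the scatter), and the true size of that step stays unknown, as compound 3 gives only a limit: the limit of > 250000 nM in this assay, at which 1 of the 4 values shown sits. The change does not bring the read-out all the way back to that of the compounds with a carbamoyl group on the nitrogen, for the remaining steps, a 5.1-fold higher number from compound 2 to compound 4 (0.71 log units; beyond the scatter) and a 7.2-fold higher number from compound 1 to compound 4 (0.86 log units; beyond the scatter), are modest but beyond the scatter. Within the data shown here, compound 4 thus gives the first number for a compound with a chain in place of the carbamoyl group, so this change can now be sized against compound 1 and compound 2 by a measured value and not by a limit.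

From the compounds shown here alone, it remains open whether the four-membered ring or the pair of carbonyl groups accounts for the lower number from compound 3 to compound 4. A pyrrolidine amide, a carboxylic acid or a primary amine at the end of the same chain, or a longer chain, could separate these parts.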